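Losing the 2,5-dioxopyrrolidin-3-yl group from compound 1

A few compounds are considered here, and "the series" means these few. Any claim that something is new, unique, unknown or untested is made for them only; others in the source may bear on it.

In a functional assay on LoVo cells (Homo sapiens) for cytotoxicity, read by MTT assay, with a stated time of 72 h (on this read-out higher numbers stand for weaker inhibition and lower numbers for stronger inhibition), compound 1 `COc1ccc2[nH]c(-c3ccc[nH]3)c(C3CC(=O)NC3=O)c2c1` gives 4000 nM and compound 3 `O=C1CC(c2c(-c3ccc[nH]3)[nH]c3ccccc23)C(=O)N1` gives 8000 nM, two values within the scatter of each other, while compound 2 `c1ccc2[nH]c(-n3cccn3)cc2c1` gives 86000 nM, well clear of both. Compound 4 `COc1ccc2[nH]c(-c3ccc[nH]3)cc2c1` differs from compound 1 in one place: hydrogen in place of 2,5-dioxopyrrolidin-3-yl on an aromatic carbon. Within the data shown here, the only measured step, a 2.0-fold higher number from compound 1 to compound 3 (0.30 log units; within the scatter), concerns methoxy and leaves this group untouched. The closest evidence is compound 2 at 86000 nM, which also has no such group but differs elsewhere too. A clear rise is therefore expected, an estimated 7.5-fold higher number from compound 1 to compound 4 (0.88 log units; beyond the scatter). For compound 4 the expected value is 30000 nM, within an estimated range of 10000 nM to 90000 nM.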

Compound 4, half-maximal inhibitory concentration: 26000 nM
Beside the measured number, compound 4's estimate is 1.2-fold (0.06 log units) above it; measured number inside the range.
By their numbers in this assay, from the lowest: compounds 1 and 3 (each within the scatter of the next); then compound 4; then compound 2.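

In this assay the change to hydrogen on this aromatic carbon gives a 6.5-fold higher number from compound 1 to compound 4 (0.81 log units; beyond the scatter) and thereby reads the 2,5-dioxopyrrolidin-3-yl group directly, whereas the earlier step changed only the methoxy and left that group in place. The lower number of compound 1 thus goes with the presence of this group on the shared core. Nothing measured here accounts for the size of the step. Still open, on these data alone, is whether the ring itself matters, or whether an amine, a carboxylic acid or an open chain ending in an amide on this carbon would serve equally.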